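The compounds below may be only part of what the source reports. "The series", "measured", "known", "first", "only" and "open" are said of these compounds alone.

Of the compounds shown here, three have been measured in an assay on CHO cells for displacement of a labelled ligand from Substance-P receptor (Homo sapiens); on this read-out lower numbers stand for stronger inhibition and higher numbers for weaker inhibition. Compound 1 `C[C@@H](O[C@@H]1[C@@H](c2ccccc2)CN(C(=O)OC(C)(C)C)[C@H]1CO)c1cc(C(F)(F)F)cc(C(F)(F)F)c1` gives 3.6 nM in this assay. Compound 2 `C[C@@H](O[C@H]1[C@H](c2ccccc2)CN(C(=O)OC(C)(C)C)[C@H]1CO)c1cc(C(F)(F)F)cc(C(F)(F)F)c1` has the same atoms and bonds as compound 1 and differs only in configuration as drawn; compound 2 gives 7.8 nM. The step of a 2.2-fold higher number from compound 1 to compound 2 (0.34 log units; beyond the scatter) rests on (the fact that compounds 1 and 2 differ only in the configuration as drawn). Compound 3 `C[C@@H](O[C@H]1CN(C(=O)OC(C)(C)C)[C@@H](CO)[C@@H]1c1ccccc1)c1cc(C(F)(F)F)cc(C(F)(F)F)c1` gives 0.63 nM, the lowest of the three numbers in this assay; compound 1 and compound 2 both sit clearly higher.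

The piece follows the step from compound 3 to compound 4 `C[C@@H](O[C@H]1CN(C(=O)OC(C)(C)C)[C@@H](CO)[C@@H]1c1ccc(F)cc1)c1cc(C(F)(F)F)cc(C(F)(F)F)c1`. The change is fluoro in place of hydrogen on an aromatic carbon, so the phenyl of compound 3 becomes a 4-fluorophenyl in compound 4. Within the data shown here, only one measured step is available, and it concerns configuration alone rather than an exchange of a hydrogen for a fluoro; it offers no direct guide to the present step. With nothing measured that resembles the change, the expectation for compound 4 is a step of about a 1.3-fold lower number from compound 3 to compound 4 (0.10 log units; within the scatter), which is no change beyond the usual scatter. Compound 4 is therefore estimated at 0.5 nM in this assay, with a range from 0.2 nM to 1.5 nM.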

Compound 4, half-maximal inhibitory concentration: 0.28 nM
Compound 4: the middle estimate sits 1.8-fold (0.25 log units) above what was measured; the measured number falls inside the stated range.
By their numbers in this assay, from the lowest: compound 4; then compound 3; then compound 1; then compound 2.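

Among these compounds, until this point, the only step in this assay concerned configuration, so the earlier compounds said nothing about how this aromatic ring responds to a new substituent. Changing phenyl to 4-fluorophenyl gives a 2.3-fold lower number from compound 3 to compound 4 (0.35 log units; beyond the scatter), which shows that the position para to a large group tolerates a fluoro and that this single atom lowers the number measurably, even though compound 3 already stands at 0.63 nM. The one thing known about these compounds concerns configuration and has no bearing on the exchange of hydrogen for fluoro, so the data offer no explanation for this step.

As far as these compounds go, this is one substituent at one place on a single stereoisomer, so it remains open whether chloro, methoxy, a nitrile or a trifluoromethyl group at the same place would lower the number as well, or whether fluoro would do so elsewhere on the ring. From the compounds shown here alone, it also remains open whether the same exchange would give a step of similar size on the configurations of compound 1 and compound 2.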